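The source may hold more compounds than are shown below. What is called first, only, known or untested is meant among the compounds shown, and "the series" means these compounds.

In a functional assay on HeLa cells (Homo sapiens) for inhibition (a higher number here means a weaker inhibitor, a lower number a stronger inhibitor), compound 1 (`Cc1cn(/C=C/C=O)c(=O)[nH]c1=O`) gives 100000 nM, the higher of the two exact numbers available. Compound 3 (`Cc1cn(COCCO)c(=O)n(/C=C/C=O)c1=O`) gives 20000 nM, a lower number by a gap beyond the scatter. Compound 2 (`Nc1ccn(/C=C/C=O)c(=O)n1`) is recorded only as a limit of the assay, > 100000 nM. Compound 4 (`O=C/C=C/n1cc(C(F)(F)F)c(=O)[nH]c1=O`) has trifluoromethyl in place of methyl on an aromatic carbon of compound 1 (trifluoromethyl in place of methyl on an aromatic carbon). Within the data shown here, no measured pair differs in only one place, so this change has no direct precedent here. A modest step towards a lower number in this assay is expected, though it may not clearly exceed the scatter. The estimated step is a 2.5-fold lower number from compound 1 to compound 4 (0.40 log units; beyond the scatter). Compound 4 is estimated at 40000 nM, with an expected range of 8000 nM to 120000 nM.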

Compound 4, half-maximal inhibitory concentration: > 100000 nM
Compound 4 gave a limit, no number; the forecaster's own chance of this, stated with the estimate: 25%; middle value at least 2.5-fold (0.39 log units) away from the limit.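

At this aromatic carbon, trifluoromethyl in place of methyl brings a number no lower from compound 1 to compound 4 (the limit leaves the size open) in this assay, the only change in one place among these compounds. Compound 4 is recorded as a limit of the assay and not a number, so the size of this step cannot be read, but the change brings no move towards a stronger inhibitor. The readable range ends at that limit: the limit of > 100000 nM in this assay, at which 2 of the 4 values shown sit.

As far as these compounds go, whether a single fluorine or a longer chain on this carbon would shift the number stays open. So does the effect of trifluoromethyl on a compound carrying the side chain of compound 3.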